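Ring substituent moves on the shared core

The source may report more compounds than this note shows. Statements on the series, on what has been measured and on what is new or still open speak of the compounds shown alone.

Compound 3 `O=C1/C(=C\c2ccccc2Cl)c2ccccc2N1c1c(Cl)cccc1Cl` gives 39 ug/mL in a functional assay on B16-F10 cells (Homo sapiens) for cytotoxicity against B16-F10 (Mus musculus), read by MTT assay, with a stated time of 72 h (on this read-out lower numbers stand for an effect already at smaller amounts and higher numbers for an effect only at larger amounts of compound), the highest number of the three, though compound 1 `O=C1/C(=C\c2ccc(O)cc2)c2ccccc2N1c1c(Cl)cccc1Cl` with 33 ug/mL lies within the scatter of it. Compound 2 `O=C1/C(=C\c2cccc(Br)c2)c2ccccc2N1c1c(Cl)cccc1Cl` gives 8 ug/mL and stands furthest off, with a 4.9-fold higher number from compound 2 to compound 3 (0.69 log units; beyond the scatter). Compound 4 `O=C1/C(=C\c2ccc(Cl)cc2)c2ccccc2N1c1c(Cl)cccc1Cl` carries the change (4-chlorophenyl in place of 2-chlorophenyl on a double-bonded chain carbon bound to a double-bonded ring carbon). Going by the values given here, no measured step swaps the two chlorophenyl groups directly. Among the compounds with values here, the nearest guide is the step of a 1.2-fold higher number from compound 1 to compound 3 (0.07 log units; within the scatter) where 4-hydroxyphenyl and 2-chlorophenyl give numbers within the scatter of each other, while the only step beyond the scatter, a 4.1-fold lower number from compound 1 to compound 2 (0.62 log units; beyond the scatter), involves 3-bromophenyl, which compound 4 lacks. A step of a 1.3-fold lower number from compound 3 to compound 4 (0.11 log units; within the scatter) is therefore expected, at most a small move to a lower number. Compound 4 is estimated at 30 ug/mL, within 12 ug/mL to 60 ug/mL.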

Compound 4, concentration for half-maximal effect: > 100 ug/mL
Compound 4: no number, only a limit; the forecaster's own chance of this, stated with the estimate: 5%; middle value at least 3.3-fold (0.52 log units) from the limit.
By their numbers in this assay, from the lowest: compound 2; then compounds 1 and 3 (each within the scatter of the next). At a limit, above all of these: compound 4.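

Compound 4 stands at a limit and not a number in this assay: the limit of > 100 ug/mL in this assay, at which 1 of the 4 values shown sits.
Moving from 2-chlorophenyl to 4-chlorophenyl, with the same atoms joined differently, gives a clear rise (an at least 2.5-fold higher number from compound 3 to compound 4 (0.40 log units; beyond the scatter)), so the site of the chloro on this phenyl counts at this place, which the earlier compounds could not show. The other steps also rise (an at least 12-fold higher number from compound 2 to compound 4 (1.09 log units; beyond the scatter); an at least 3.0-fold higher number from compound 1 to compound 4 (0.48 log units; beyond the scatter)), the latter with chloro in place of hydroxy on an aromatic carbon.

Still open, on these data alone, is how 3-chlorophenyl would read, since halogen and site both change between compound 2 and compound 4. As far as these compounds go, how an aminophenyl would read at this place also stays open.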